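Cyclopropyl in place of methyl on the pyrazole of compound 2

The source may hold more compounds than are shown below. What is called first, only, known or untested is meant among the compounds shown, and "the series" means these compounds.

Two compounds were measured in an assay on cells for inhibition of MAP kinase-interacting serine/threonine-protein kinase 1 (Homo sapiens), read by mobility shift assay, with stated times of 10 min and 60 min, in the presence of a further agent that is not named here; a higher number here means a weaker inhibitor, a lower number a stronger inhibitor:
compound 1, `CCOc1cc(-c2cccnc2)ccc1C(N)=O`, gives 2200 nM;
compound 2, `Cc1[nH]ncc1-c1cncc(-c2ccc(C(N)=O)c(OC(C)C)c2)c1`, gives 54 nM.

Among the measured compounds shown here, compound 2 holds the lowest of the two numbers; its nearest neighbour, compound 1, sits far higher, beyond the scatter, though no step between the pair is worked out here. Compound 3, `CC(C)Oc1cc(-c2cncc(-c3c[nH]nc3C3CC3)c2)ccc1C(N)=O`, differs from compound 2 by 3-cyclopropyl-1H-pyrazol-4-yl in place of 5-methyl-1H-pyrazol-4-yl on an aromatic carbon. For the measured compounds named here, no measured step covers such a change, so compound 3 is expected to stay within the scatter of compound 2, a step of a 1.1-fold higher number from compound 2 to compound 3 (0.05 log units; within the scatter). Compound 3 is thus estimated at 60 nM, between 20 nM and 180 nM.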

Compound 3, half-maximal inhibitory concentration: 130 nM
Compound 3: the middle estimate sits 2.2-fold (0.34 log units) below what was measured; the measured number falls inside the stated range.
By their numbers in this assay, from the lowest: compound 2; then compound 3; then compound 1.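

In this assay, the pyrazole substituent on this aromatic carbon proves sensitive to change: 3-cyclopropyl-1H-pyrazol-4-yl in place of 5-methyl-1H-pyrazol-4-yl gives a 2.4-fold higher number from compound 2 to compound 3 (0.38 log units; beyond the scatter). The step is modest, but the cyclopropyl group brings no gain over methyl here. Nothing available accounts for this loss. The compounds shown leave open how a pyrazole carrying ethyl, trifluoromethyl or an amine in that place would compare with compound 2, and whether a pyrazole with only hydrogen there would keep its value.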